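Ring Contraction at the Aromatic Nitrogen of Compound 3

A few compounds are considered here, and "the series" means these few. Any claim that something is new, unique, unknown or untested is made for them only; others in the source may bear on it.

Compound 3 `CN1CCN(c2ccc(Nc3ncc4nc(Nc5ccc(F)cc5)n([C@@H]5CCCN(C(=O)CO)C5)c4n3)cc2)CC1` stands second highest of the three numbers in a functional assay on HCC827 cells (Homo sapiens) for antiproliferative activity, read by MTT assay, with a stated time of 72 h (a higher number here means a weaker inhibitor, a lower number a stronger inhibitor), where compound 3 gives 66 nM. Compound 1 `CC(=O)Nc1cccc(-n2c(Nc3ccc(F)cc3)nc3cnc(Nc4ccc(N5CCN(C)CC5)cc4)nc32)c1` gives 10 nM, with a 6.6-fold higher number from compound 1 to compound 3 (0.82 log units; beyond the scatter). Compound 2 `CNC(=O)CN1CC[C@H](n2c(Nc3ccc(F)cc3)nc3cnc(Nc4ccc(N5CCN(C)CC5)cc4)nc32)C1` gives 1520 nM, with a 23-fold lower number from compound 2 to compound 3 (1.36 log units; beyond the scatter). Compound 4 `CN1CCN(c2ccc(Nc3ncc4nc(Nc5ccc(F)cc5)n([C@@H]5CCN(C(=O)CO)C5)c4n3)cc2)CC1` carries 1-((hydroxymethyl)carbonyl)pyrrolidin-3-yl in place of 1-((hydroxymethyl)carbonyl)piperidin-3-yl on an aromatic nitrogen. The step bearing most on it is a 23-fold lower number from compound 2 to compound 3 (1.36 log units; beyond the scatter), though there the 1-((methylcarbamoyl)methyl)pyrrolidin-3-yl group also differed in its substituent; a 150-fold higher number from compound 1 to compound 2 (2.18 log units; beyond the scatter) and a 6.6-fold higher number from compound 1 to compound 3 (0.82 log units; beyond the scatter) show both saturated rings weaker than the 3-acetamidophenyl of compound 1, the pyrrolidine more so. A modest weakening is therefore expected for compound 4, a 2.4-fold higher number from compound 3 to compound 4 (0.38 log units; beyond the scatter). Compound 4 is estimated at 160 nM, between 50 nM and 500 nM.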

Compound 4, half-maximal inhibitory concentration: 350 nM
For compound 4 the middle estimate is 2.2-fold (0.34 log units) below the measured one, within the range that was stated.
By their numbers in this assay, from the lowest: compound 1; then compound 3; then compound 4; then compound 2.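

Among the compounds shown here, with the 1-((hydroxymethyl)carbonyl) substituent held constant, ring size at this aromatic nitrogen is read on its own for the first time, and the piperidin-3-yl to pyrrolidin-3-yl change gives a 5.3-fold higher number from compound 3 to compound 4 (0.72 log units; beyond the scatter) in this assay. With the pyrrolidin-3-yl ring held instead, the substituent also counts, with a 4.3-fold lower number from compound 2 to compound 4 (0.64 log units; beyond the scatter), yet the 3-acetamidophenyl group stays well ahead, with a 35-fold higher number from compound 1 to compound 4 (1.54 log units; beyond the scatter). Nothing available offers a reason for these steps. The compounds shown leave open how an azetidin-3-yl ring, or a carboxylic acid on the ring nitrogen's substituent, would read here.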